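Oleyl chain carrying a ketone: acetal to methyltetrazole

The compounds below may be only part of what the source reports. "The series", "measured", "known", "first", "only" and "open" are said of these compounds alone.

The series is judged in an assay on isolated protein for inhibition of Fatty-acid amide hydrolase 1 (Homo sapiens); a higher number here means a weaker inhibitor, a lower number a stronger inhibitor. Compound 1 `CCCCCCCCCCCCCC(=O)C(F)(F)F` gives 490 nM. Compound 3 `CCCCCCCC/C=C\CCCCCCC(=O)c1nc2c(C)cccc2o1` reaches only a limit of the assay, > 100000 nM, and this is the limit described at the limit of > 100000 nM in this assay, at which 1 of the 3 values shown sits. Compound 2 `CCCCCCCC/C=C\CCCCCCCC(OC)OC` likewise returns only a limit, > 300000 nM, the limit described at the limit of > 300000 nM in this assay, at which 1 of the 3 values shown sits. Compound 2 therefore stands among the two limits that make up the weaker end of what has been measured, with compound 1 alone giving a number.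

Compound 4 `CCCCCCCC/C=C\CCCCCCC(=O)c1nnn(C)n1` differs from compound 2 by (2-methyl-2H-tetrazol-5-yl)carbonyl in place of 2,2-dimethoxyethyl on a saturated chain carbon, six bonds along the chain from a double-bonded chain carbon. Compound 1 with its 490 nM shows that a chain of this kind ending in an activated carbonyl can give a measurable inhibition constant, while compound 3 shows that a carbonyl joined to an aromatic ring does not always do so. Among the measured compounds shown here, no step between measured compounds is available, so the expectation rests on these two values alone: the step from compound 2 to compound 4 is expected to be large and toward stronger inhibition, an at least 150-fold lower number from compound 2 to compound 4 (2.17 log units; beyond the scatter). For compound 4 the inhibition constant is estimated at 2000 nM, between 100 nM and 50000 nM.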

Compound 4, inhibition constant: 65 nM
The estimate for compound 4 lay 31-fold (1.49 log units) above the measured number; measured number outside the range, below it.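

Placing (2-methyl-2H-tetrazol-5-yl)carbonyl in place of 2,2-dimethoxyethyl on a saturated chain carbon, six bonds along the chain from a double-bonded chain carbon, gives an at least 4600-fold lower number from compound 2 to compound 4 (3.66 log units; beyond the scatter) in this assay. Compound 2 stands at a limit of the assay, so this step is a bound and not an exact size: the limit of > 300000 nM in this assay, at which 1 of the 4 values shown sits. Compound 4 shows that on this chain a carbonyl carrying a ring can give a measured number, while compound 3, which differs from it only in the ring, remains a limit: the limit of > 100000 nM in this assay, at which 1 of the 4 values shown sits.

The compounds shown leave open how much of the step belongs to the carbonyl and how much to the tetrazole ring. They also leave open whether an ethyl group in place of the methyl on that ring, or a carboxylic acid on it, would keep the inhibition.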